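The source may hold more compounds than are shown below. What is called first, only, known or untested is meant among the compounds shown, and "the series" means these compounds.

Compounds measured so far:
- compound 1, `CNC(=O)[C@@]12C[C@@H]1[C@@H](n1cnc3c(NC)nc(C#Cc4cccnc4)nc31)[C@H](O)[C@@H]2O`, 2.15 nM
- compound 2, `CNC(=O)[C@@]12C[C@@H]1[C@@H](n1cnc3c(NC)nc(C#Cc4cc(C)c(C)o4)nc31)[C@H](O)[C@@H]2O`, 1.45 nM

Both values come from an assay on CHO cells for displacement of a labelled ligand from adenosine receptor A3 (Homo sapiens), read by scintillation counting, with a stated time of 60 min; a lower number here means a stronger inhibitor, a higher number a weaker inhibitor. Compound 2 has the lowest of the two numbers, and its nearest neighbour is compound 1, but the step of a 1.5-fold lower number from compound 1 to compound 2 (0.17 log units; within the scatter) lies within the scatter, so the two cannot be set in order on these data alone.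

Compound 3, `CCc1ccc(C#Cc2nc(NC)c3ncn([C@H]4[C@H](O)[C@H](O)[C@]5(C(=O)NC)C[C@H]45)c3n2)o1`, has not yet been measured. It differs from compound 2 in one place: 5-ethylfuran-2-yl in place of 4,5-dimethylfuran-2-yl on a triple-bonded carbon. The leaving and the entering group count the same atoms and the same ring type, only arranged differently.

For the measured compounds named here, only one measured step bears on this change: the exchange of the group on the triple-bonded carbon, where a 1.5-fold lower number from compound 1 to compound 2 (0.17 log units; within the scatter) was within the scatter even though a pyridine ring was traded for a furan ring. A rearrangement within the furan ring is a smaller change than that. The expected step of a 1.1-fold higher number from compound 2 to compound 3 (0.04 log units; within the scatter) is therefore no change beyond the scatter. For compound 3 the estimated value in this assay is 1.6 nM, within a range of 0.7 nM to 4 nM.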

Compound 3, inhibition constant: 1.5 nM
The estimate for compound 3 lay 1.1-fold (0.03 log units) above the measured number; measured number inside the range.
By their numbers in this assay, from the lowest: compounds 2, 3 and 1 (each within the scatter of the next).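

In this assay the change from 4,5-dimethylfuran-2-yl to 5-ethylfuran-2-yl on the triple-bonded carbon gave a 1.0-fold higher number from compound 2 to compound 3 (0.01 log units; within the scatter) and the exchange of pyridin-3-yl for 5-ethylfuran-2-yl gave a 1.4-fold lower number from compound 1 to compound 3 (0.16 log units; within the scatter) as well. The earlier compounds had shown only that one furan could take the place of the pyridine ring; the new result adds that rearranging the same carbons around the furan ring, from two methyl groups to one ethyl group, leaves the number within the scatter, so compound 1, compound 2 and compound 3 cannot be set in order and this position accepted all three groups without a readable difference. Nothing available accounts for this lack of difference.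

The compounds shown leave open whether the same holds for a group of another kind on the triple-bonded carbon, such as an amine, a carboxylic acid or a longer alkyl chain, since each group seen so far is a single aromatic ring. Only this assay is shown here and the behaviour of these compounds at other adenosine receptors stays open.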